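Urea series: carbonyl substituent and solubility at low pH

The source may report more compounds than this note shows. Statements on the series, on what has been measured and on what is new or still open speak of the compounds shown alone.

Measured so far:
compound 1 `O=C(Nc1ccc(OC(F)(F)F)cc1)NC1CCN(C(=O)C2CCOCC2)CC1`: 1300 ug/mL
compound 2 `O=C(Nc1ccc(C(F)(F)F)cc1)NC1CCN(C(=O)C2CCOC2)CC1`: 50 ug/mL
compound 3 `O=C(Nc1ccc(OC(F)(F)F)cc1)NC1CCN(C(=O)C2CCOC2)CC1`: 91 ug/mL

Of the compounds shown here, three on a shared core have been read in a physicochemical assay for solubility, read by mass spectrometry, in phosphate buffer, with a stated time of 24 h, at pH 3; on this read-out lower numbers stand for lower solubility and higher numbers for higher solubility. Compound 2 has the lowest of the three numbers; its nearest neighbour is compound 3, with a 1.8-fold higher number from compound 2 to compound 3 (0.26 log units; within the scatter), within the scatter, whereas its gap to compound 1 lies beyond the scatter. For the measured compounds named here, the one large step seen so far is a 14-fold lower number from compound 1 to compound 3 (1.15 log units; beyond the scatter), a change of the group on the carbonyl carbon.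

Compound 4 `O=C(Nc1ccc(C(F)(F)F)cc1)NC1CCN(C(=O)c2cc[nH]c2)CC1` differs from compound 2 by 1H-pyrrol-3-yl in place of oxolan-3-yl on a carbonyl carbon. Going by the values given here, no measured step swaps the ring at this position for an aromatic one, so none bears directly; the step from compound 1 to compound 3 shows only that changes at this carbonyl carbon can move the number a good deal. On that basis compound 4 is expected to show a 1.7-fold lower number from compound 2 to compound 4 (0.22 log units; within the scatter), downward, of uncertain size. The estimate for compound 4 is 30 ug/mL, with a range from 8 ug/mL to 120 ug/mL.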

Compound 4, solubility: 13 ug/mL
Compound 4: the middle estimate sits 2.3-fold (0.36 log units) above what was measured, within the range that was stated.
By their numbers in this assay, from the lowest: compound 4; then compounds 2 and 3 (each within the scatter of the next); then compound 1.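

In this assay, moving from oxolan-3-yl to 1H-pyrrol-3-yl on a carbonyl carbon gives a 3.8-fold lower number from compound 2 to compound 4 (0.59 log units; beyond the scatter), so replacing this non-aromatic ring with an aromatic five-membered ring moves the number beyond the scatter. The earlier step at this position, a 14-fold lower number from compound 1 to compound 3 (1.15 log units; beyond the scatter), links two non-aromatic rings, whereas the new step also brings in a hydrogen-bond donor and removes a hydrogen-bond acceptor. These counts change together with aromaticity and the hetero atom, and no supporting measurement separates them or accounts for the step.

On these data alone, whether the same change gives a similar step with trifluoromethoxy on the aromatic carbon remains open. Also open, as far as these compounds go, is how a group carrying an amine or a carboxylic acid on this carbonyl carbon would read in this assay.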